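Swapping a Trifluoromethyl for a Methylcarbamoyl Group

A few compounds are considered here, and "the series" means these few. Any claim that something is new, unique, unknown or untested is made for them only; others in the source may bear on it.

Of the compounds shown here, three built on a shared core have been measured in an in vitro ADME assay on microsomes from liver (Homo sapiens) for metabolic stability; a lower number here means slower removal, a higher number faster removal of the compound. Compound 1 `COc1ccc(-c2cc(-c3cccc(S(C)(=O)=O)c3)cnc2N)cn1` gives 7.6 mL.min-1.g-1. Compound 2 `COc1ccc(-c2cc(-c3ccc(C(F)(F)F)cc3)cnc2N)cn1` gives 6.1 mL.min-1.g-1. Compound 3 `COc1ccc(-c2cc(-c3ccc4cnn(C)c4c3)cnc2N)cn1` gives 12 mL.min-1.g-1. The three numbers sit close together: compound 1 lies within the usual scatter of compound 2, and so does compound 3, so none of the three can be set apart from the others on this evidence.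

Compound 4 `CNC(=O)c1ccc(-c2cnc(N)c(-c3ccc(OC)nc3)c2)cc1` has not been measured. It differs from compound 2 in one place: methylcarbamoyl in place of trifluoromethyl on an aromatic carbon. Among the compounds with values here, no measured pair shows this particular swap, so there is nothing here to say how far the number should move, or in which direction. What the three measured compounds do show is that three different groups hung on the same shared core all give numbers within the scatter of one another in this assay. On that basis only a small step is expected, a 1.1-fold higher number from compound 2 to compound 4 (0.03 log units; within the scatter), with no direction beyond the scatter. Compound 4 is therefore estimated at 6.5 mL.min-1.g-1, with a range expected from 3 mL.min-1.g-1 to 14 mL.min-1.g-1.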

Compound 4, intrinsic clearance in microsomes: < 7 mL.min-1.g-1
Compound 4 ended at the assay's limit; the forecaster's own chance of this, stated with the estimate: 5%; the middle value does not contradict the limit.
By their numbers in this assay, from the lowest: compounds 2, 1 and 3 (each within the scatter of the next).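

In this assay compound 4 gives < 7 mL.min-1.g-1 as a limit of the assay and not as a number. With a limit in place of a number, no step can be read between compound 2 and compound 4. As far as these compounds go, whether methylcarbamoyl in place of trifluoromethyl on an aromatic carbon moves the number at all, and in which direction, stays open.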